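The source may hold more compounds than are shown below. What is called first, only, known or untested is meant among the compounds shown, and "the series" means these compounds.

Measured so far:
Compound 1 `CSc1nc(N)c2nc(O)n(Cc3ccccc3)c2n1` gives 0.1 uM in a functional assay (spleen, spleen) for activation, with Mus musculus as the target; on this read-out higher numbers stand for an effect only at larger amounts of compound and lower numbers for an effect already at smaller amounts.
Compound 2 `COc1nc2c(N)ncnc2n1Cc1ccccc1` gives in this assay only a limit, > 10 uM.

Compound 1 holds the only actual number shown here; the other entry is a limit, (the limit of > 10 uM in this assay, at which 1 of the 2 values shown sits). Compound 3 `CCCCc1nc(N)c2nc(O)n(Cc3ccccc3)c2n1` has not yet been measured. It differs from compound 1 by butyl in place of methylsulfanyl on an aromatic carbon. For the measured compounds named here, no step between two measured compounds is available to guide the size of such a change. Butyl in place of methylsulfanyl is expected to leave the outcome roughly where it is, so the step of a 3.0-fold higher number from compound 1 to compound 3 (0.48 log units; beyond the scatter) is expected to fall within the usual scatter or be a modest loss. Compound 3 is therefore estimated at 0.3 uM, between 0.05 uM and 3 uM.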

Compound 3, minimum effective concentration: 0.03 uM
Beside the measured number, compound 3's estimate is 10-fold (1.00 log units) above it; measured number below the stated range.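

Placing butyl instead of methylsulfanyl on this aromatic carbon, between two ring nitrogen atoms, gives a 3.3-fold lower number from compound 1 to compound 3 (0.52 log units; beyond the scatter) in this assay. So this position accepts a chain made only of carbon, and sulfur is not needed there for the effect to appear at small amounts. Nothing shown gives a reason for this step.

A single pair cannot show a trend with chain length. As far as these compounds go, whether a longer chain such as hexyl, or an amine at this position, would lower the number further remains open.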